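Methyl on the pyridine ring: thiosemicarbazone cytotoxicity in A-431 cells

This account rests on a few compounds, and the source may have more. Where it says the series, first, only, none or still open, it means among the compounds named here.

Compound 1 `N/C(=N\NC(=S)N1CCCCCC1)c1ccccn1`, compound 2 `N/C(=N\NC(=S)N1CCOCC1)c1ccccn1` and compound 3 `Cc1ccnc(/C(N)=N/NC(=S)N2CCOCC2)c1` were tested in a functional assay on A-431 cells (Homo sapiens) for cytotoxicity, read by MTT assay, with a stated time of 72 h; a higher number here means a weaker inhibitor, a lower number a stronger inhibitor. Compound 1 gives 3000 nM, compound 2 gives 4800 nM and compound 3 gives 6800 nM. The difference between the cores of compound 1 and compound 2 is not broken down here. Compound 2 and compound 3 differ by one change, (methyl in place of hydrogen on an aromatic carbon), and in this assay it made a 1.4-fold higher number from compound 2 to compound 3 (0.15 log units; within the scatter). Compound 4 `Cc1ccnc(/C(N)=N/NC(=S)N2CCCCCC2)c1` has not yet been measured; it differs from compound 1 by the same change, (methyl in place of hydrogen on an aromatic carbon). Because the measured step was a 1.4-fold higher number from compound 2 to compound 3 (0.15 log units; within the scatter), the step from compound 1 to compound 4 is expected to be a 1.4-fold higher number from compound 1 to compound 4 (0.15 log units; within the scatter). Compound 4 is therefore estimated at 4200 nM in this assay, with a likely range from 2000 nM to 9000 nM.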

Compound 4, half-maximal inhibitory concentration: 8000 nM
Estimate against measurement, compound 4: 1.9-fold (0.28 log units) below, within the range that was stated.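

In this assay, methyl in place of hydrogen on an aromatic carbon gave a 2.7-fold higher number from compound 1 to compound 4 (0.43 log units; beyond the scatter) on the core of compound 1. That step lies beyond the scatter and the earlier one within it, yet the two do not differ beyond the scatter: the same change on two cores in this assay, a 1.4-fold higher number (0.15 log units; within the scatter) from compound 2 to compound 3 and a 2.7-fold higher number (0.43 log units; beyond the scatter) from compound 1 to compound 4, 1.9-fold (0.27 log units) apart, within the scatter of two such steps. The change can therefore be carried between these two cores as a rough guide to size, but two cores do not show that this holds across the series, and the data do not explain either step.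

The compounds shown leave open whether ethyl, methoxy or chlorine opposite the ring nitrogen would carry over between these cores in the same way.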